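Swapping methylsulfanyl for methylamino on a shared nucleoside core

The source may hold more compounds than are shown below. What is called first, only, known or untested is meant among the compounds shown, and "the series" means these compounds.

Measured so far:
compound 1, `CN(C)c1nc(N)c2ncn([C@@H]3C[C@@H](O)[C@H](CO)O3)c2n1`: 125 uM
compound 2, `CSc1nc(SC)c2ncn([C@@H]3C[C@@H](O)[C@H](CO)O3)c2n1`: 170 uM

Of the compounds shown here, two have been tested in a functional assay on Raji cells (Homo sapiens); a lower number here means a stronger inhibitor, a higher number a weaker inhibitor. Compound 1 `CN(C)c1nc(N)c2ncn([C@@H]3C[C@@H](O)[C@H](CO)O3)c2n1` gives 125 uM and compound 2 `CSc1nc(SC)c2ncn([C@@H]3C[C@@H](O)[C@H](CO)O3)c2n1` gives 170 uM. Of these two numbers compound 2 carries the larger one, but the gap to compound 1 lies within the usual scatter of this assay, so the two compounds cannot be told apart on these data. Compound 3 `CNc1nc(SC)nc2c1ncn2[C@@H]1C[C@@H](O)[C@H](CO)O1` has not yet been tested. It differs from compound 2 in one place: methylamino in place of methylsulfanyl on an aromatic carbon. Within the data shown here, no step between measured compounds covers a change of this kind, and the two compounds measured so far sit close together even though they carry quite different groups on the shared core. No change beyond the scatter is expected here, at most a slight lean toward a lower number: the estimated step is a 1.4-fold lower number from compound 2 to compound 3 (0.15 log units; within the scatter). Compound 3 is accordingly expected to give 120 uM, within a range from 40 uM to 400 uM.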

Compound 3, concentration for 50% inhibition: > 300 uM
Compound 3: a limit, no number; the forecaster's own chance of this, stated with the estimate: 20%; at least 2.5-fold (0.39 log units) between middle value and limit.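

In this assay, methylamino in place of methylsulfanyl on this aromatic carbon gives an at least 1.7-fold higher number from compound 2 to compound 3 (0.24 log units; that floor lies within the scatter). Compound 3 carries a limit and not a number, so this step has a floor but no known size: the limit of > 300 uM in this assay, at which 1 of the 3 values shown sits.

At this position, then, the swap gives no sign of a stronger inhibitor, although the floor alone does not separate the two compounds beyond the scatter.

The compounds shown leave open whether any other group on this carbon, such as a plain amine or a longer chain like ethylsulfanyl, would give a lower number. They also leave open whether the same swap at the remaining methylsulfanyl group would give a similar result.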